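The source may report more compounds than this note shows. Statements on the series, on what has been measured and on what is new or still open speak of the compounds shown alone.

In an ADME assay on Vero cells (Chlorocebus sabaeus) for cytotoxicity, read by MTT assay, with a stated time of 72 h (a higher number here means that more compound is needed for the effect, a lower number that less compound is needed), compound 1 `Cc1ccccc1C(=O)Nc1nc(-c2ccccn2)cs1` gives 6300 nM and compound 2 `Cc1cccc(C(=O)Nc2nc(-c3ccccn3)cs2)c1` gives 4100 nM. Going by the values given here, these two numbers lie within the scatter of each other, so compound 2 stands level with the only other measured compound. Compound 3 `COc1cccc(C(=O)Nc2nc(-c3ccccn3)cs2)c1` differs from compound 2 in one place: methoxy in place of methyl on an aromatic carbon. This puts methoxy in place of methyl on an aromatic carbon, meta to a large group. Among the compounds with values here, the one measured step that bears on this change is a 1.5-fold lower number from compound 1 to compound 2 (0.19 log units; within the scatter), and it lies within the scatter. Within the data shown here, that step moves the methyl group and does not replace it, so the data hold no direct precedent for methoxy. No step beyond the scatter is therefore expected in this assay. Compound 3 is estimated at 4500 nM, with an expected range from 2000 nM to 10000 nM. That estimate means an expected 1.1-fold higher number from compound 2 to compound 3 (0.04 log units; within the scatter).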

Compound 3, half-maximal effective concentration: 2800 nM
Beside the measured number, compound 3's estimate is 1.6-fold (0.21 log units) above it; measured number inside the range.
By their numbers in this assay, from the lowest: compounds 3, 2 and 1 (each within the scatter of the next, the first and the last beyond it).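

In this assay the change from methyl to methoxy on this aromatic carbon, meta to a large group, gives a 1.5-fold lower number from compound 2 to compound 3 (0.17 log units; within the scatter) and so stays level. Going by these compounds alone, this is the first direct reading of methoxy at this position: the earlier step only moved the methyl group, whereas this one adds a carbon-bound oxygen and one hydrogen-bond acceptor without a step beyond the scatter. No measurement given here accounts for the result.

Going by these compounds, whether a group of another kind on this carbon, such as an amine or a carboxylic acid, would give a step beyond the scatter stays open. So does the effect of methoxy at the position where compound 1 carries its methyl group.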